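Shortening the side chain of a nucleoside inhibitor

The source may report more compounds than this note shows. Statements on the series, on what has been measured and on what is new or still open speak of the compounds shown alone.

Measured so far:
compound 1 `OC[C@H]1O[C@@H](n2cnc3c(COc4ccccn4)ncnc32)[C@H](O)[C@@H]1O`: 16600 nM
compound 2 `OC[C@H]1O[C@@H](n2cnc3c(CSCc4ccccc4)ncnc32)[C@H](O)[C@@H]1O`: 9200 nM

In a functional assay on CCRF-CEM cells (Homo sapiens) for inhibition, with a stated time of 72 h (a lower number here means a stronger inhibitor, a higher number a weaker inhibitor), compound 1 gives 16600 nM, the highest of the two numbers; in this assay compound 2 gives 9200 nM. Among the compounds with values here, the only measured step, a 1.8-fold lower number from compound 1 to compound 2 (0.26 log units; within the scatter), is within the scatter. Compound 3 `COCc1ncnc2c1ncn2[C@@H]1O[C@H](CO)[C@@H](O)[C@H]1O` differs from compound 1 by methyl in place of pyridin-2-yl on an oxygen on a saturated carbon. Within the data shown here, no measured pair mirrors this change, and the one step on the same chain carbon was small, so the expected movement, a 1.1-fold lower number from compound 1 to compound 3 (0.04 log units; within the scatter), stays within the scatter. For compound 3 in this assay the estimate is 15000 nM, with a range from 5000 nM to 50000 nM.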

Compound 3, half-maximal inhibitory concentration: 6000 nM
Beside the measured number, compound 3's estimate is 2.5-fold (0.40 log units) above it; the measured number falls inside the stated range.
By their numbers in this assay, from the lowest: compounds 3, 2 and 1 (each within the scatter of the next, the first and the last beyond it).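

In this assay, within the data shown here, methyl in place of pyridin-2-yl on the oxygen gives a 2.8-fold lower number from compound 1 to compound 3 (0.44 log units; beyond the scatter), the first step on this chain to pass the scatter, and it shows that the side chain keeps its activity without an aromatic ring. Methoxy in place of benzylsulfanyl gives a 1.5-fold lower number from compound 2 to compound 3 (0.19 log units; within the scatter), so these two compounds cannot be ranked. Nothing available explains either step. As far as these compounds go, whether an amine or a carboxylic acid on this chain carbon would move the number remains open. So does whether an ethoxy or longer alkoxy chain would behave like methoxy.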